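The source may report more compounds than this note shows. Statements on the series, on what has been measured and on what is new or still open speak of the compounds shown alone.

Measured in a functional assay on A549 cells (Homo sapiens) for inhibition, read by MTT assay, with a stated time of 72 h; on this read-out higher numbers stand for weaker inhibition and lower numbers for stronger inhibition:
Compound 1 `Cc1ccc(NC(=O)CCC(=O)OCCCCCCSc2ccc([N+](=O)[O-])c3nonc23)cc1`: 5240 nM
Compound 2 `COc1ccc(NC(=O)CCC(=O)OCCCCCCSc2ccc([N+](=O)[O-])c3nonc23)cc1`: 6480 nM
Compound 3 `O=C(CCC(=O)OCCCCCCSc1ccc([N+](=O)[O-])c2nonc12)Nc1ccc(F)c(Cl)c1`: 3210 nM

Two steps show where compound 3 stands: a 2.0-fold lower number from compound 2 to compound 3 (0.31 log units; beyond the scatter), and a 1.6-fold lower number from compound 1 to compound 3 (0.21 log units; within the scatter). Compound 4 `O=C(CCC(=O)N1CCCCC1)OCCCCCCSc1ccc([N+](=O)[O-])c2nonc12` keeps the shared core and chain but carries a different end group: piperidin-1-yl in place of (3-chloro-4-fluorophenyl)amino on a carbonyl carbon. The measured steps bear on this only loosely. Those two, along with a 1.2-fold higher number from compound 1 to compound 2 (0.09 log units; within the scatter), exchange one substituted phenyl for another, and none shows what happens when the aromatic ring and the amide hydrogen leave. All three steps were small, so no large step is expected in this assay. The direction is weakly held, but a modest move towards a higher number is expected, into the range spanned by compound 1 and compound 2. The expected change is a 1.6-fold higher number from compound 3 to compound 4 (0.19 log units; within the scatter). Compound 4 is estimated at 5000 nM, with an expected range from 2000 nM to 12000 nM.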

Compound 4, half-maximal inhibitory concentration: 2510 nM
Beside the measured number, compound 4's estimate is 2.0-fold (0.30 log units) above it; the measured number falls inside the stated range.
By their numbers in this assay, from the lowest: compounds 4, 3, 1 and 2 (each within the scatter of the next, the first and the last beyond it).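

In this assay, the aromatic ring and the amide hydrogen leave this carbonyl carbon together with no change beyond the scatter: piperidin-1-yl in place of (3-chloro-4-fluorophenyl)amino gives a 1.3-fold lower number from compound 3 to compound 4 (0.11 log units; within the scatter). Among the compounds shown here, measured against the other two phenyl amides, the same kind of exchange gives a 2.6-fold lower number from compound 2 to compound 4 (0.41 log units; beyond the scatter) and a 2.1-fold lower number from compound 1 to compound 4 (0.32 log units; beyond the scatter), both modest, so a non-aromatic ring without a hydrogen-bond donor is tolerated here, which the earlier compounds, all substituted phenyl amides, could not show. Nothing among the data shown gives a reason for this result.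

The compounds shown leave open whether other groups on this carbonyl carbon, such as morpholin-4-yl, diethylamino or a free carboxylic acid, would hold the number in the same range. As far as these compounds go, whether a longer chain would shift these numbers also remains open.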